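The source may report more compounds than this note shows. Statements on the series, on what has been measured and on what is new or still open speak of the compounds shown alone.

Compound 1 `CCCOc1nc(C(C)(C)C)ccc1CNC(=O)C(C)c1ccc(NS(C)(=O)=O)c(F)c1` and compound 2 `CC(C(=O)NCc1ccc(C(C)(C)C)nc1OC1CCCC1)c1ccc(NS(C)(=O)=O)c(F)c1` were both measured in an assay on cells for antagonist activity at transient receptor potential cation channel subfamily V member 1 (Homo sapiens), read by FLIPR and calcium flux, with a stated time of 6 min; on this read-out higher numbers stand for weaker inhibition and lower numbers for stronger inhibition. Compound 1 gives 1.7 nM, and compound 2 gives 1.5 nM; the two numbers lie within the scatter of each other, as the step of a 1.1-fold lower number from compound 1 to compound 2 (0.05 log units; within the scatter) shows. Compound 3 `CCCCCCSc1nc(C(C)(C)C)ccc1CNC(=O)C(C)c1ccc(NS(C)(=O)=O)c(F)c1` carries a further change at the same place, (hexylsulfanyl in place of cyclopentyloxy on an aromatic carbon). Among the measured compounds shown here, the only step that bears on it, a 1.1-fold lower number from compound 1 to compound 2 (0.05 log units; within the scatter), was within the scatter, but the present change is larger and has no direct counterpart among the measured compounds. Compound 3 is therefore expected to show a 2.0-fold higher number from compound 2 to compound 3 (0.30 log units; within the scatter), and its estimated value in this assay is 3 nM, in a range from 1 nM to 10 nM.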

Compound 3, inhibition constant: 1.5 nM
Compound 3: the middle estimate sits 2.0-fold (0.30 log units) above what was measured, within the range that was stated.
By their numbers in this assay, from the lowest: compounds 2, 3 and 1 (each within the scatter of the next).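

Hexylsulfanyl, an open chain joined through sulfur, stands at this position, on an aromatic carbon next to the ring nitrogen, without a shift beyond the scatter from cyclopentyloxy, with no change at the digits printed from compound 2 to compound 3 (within the scatter). The comparison with propoxy agrees, with a 1.1-fold lower number from compound 1 to compound 3 (0.05 log units; within the scatter), so the position has now carried ring and open chains, joined through oxygen or sulfur, with no step beyond the scatter. Nothing measured here accounts for this. The effects of the sulfur and of the chain length remain unseparated in compound 3. As far as these compounds go, whether an amine or a carboxylic acid at this position would fit the same pattern stays open.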